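From 4-methylphenyl to 4-chlorophenyl: working notes

The compounds below may be only part of what the source reports. "The series", "measured", "known", "first", "only" and "open" are said of these compounds alone.

In a functional assay on T47D cells (Homo sapiens) for cytotoxicity, read by MTT assay, with a stated time of 3 h (on this read-out higher numbers stand for weaker inhibition and lower numbers for stronger inhibition), compound 1 `O=C(CN1CCN(c2cc(=O)[nH]c3ccc(F)cc23)CC1)Nc1nc(-c2ccccc2)cs1` gives 7200 nM and compound 2 `Cc1ccc(-c2csc(NC(=O)CN3CCN(c4cc(=O)[nH]c5ccc(F)cc45)CC3)n2)cc1` gives 8410 nM within the scatter of each other. Compound 3 `O=C(CN1CCN(c2cc(=O)n(-c3ccccc3)c3ccccc23)CC1)Nc1nc(-c2ccc(Cl)cc2)cs1` has a different core, gives 30200 nM and stands beyond the scatter above compound 2. Compound 4 `O=C(CN1CCN(c2cc(=O)[nH]c3ccc(F)cc23)CC1)Nc1nc(-c2ccc(Cl)cc2)cs1` is unmeasured and differs from compound 2 as follows: chloro in place of methyl on an aromatic carbon with chloro in place of methyl on an aromatic carbon. Within the data shown here, the only measured step at this place is a 1.2-fold higher number from compound 1 to compound 2 (0.07 log units; within the scatter) for methyl in place of hydrogen, and it lies within the scatter. Among the measured compounds shown here, compound 3 also carries 4-chlorophenyl, but its core differs and no measured step links it. The expected change is a 1.1-fold lower number from compound 2 to compound 4 (0.05 log units; within the scatter) and nothing beyond the scatter is expected. For compound 4 the estimated value is 7500 nM with an expected range from 3500 nM to 16000 nM on this read-out.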

Compound 4, half-maximal inhibitory concentration: 2730 nM
For compound 4 the middle estimate is 2.7-fold (0.44 log units) above the measured one, outside the stated range (below it).
By their numbers in this assay, from the lowest: compound 4; then compounds 1 and 2 (each within the scatter of the next); then compound 3.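

Swapping the substituent at this position does change the number in this assay: chloro in place of methyl gives a 3.1-fold lower number from compound 2 to compound 4 (0.49 log units; beyond the scatter) and chloro in place of hydrogen gives a 2.6-fold lower number from compound 1 to compound 4 (0.42 log units; beyond the scatter) on the shared core. Methyl in place of hydrogen had stayed within the scatter, so this position is not indifferent to what it carries, and chloro and methyl do not read alike here.

Going by these compounds, whether a fluoro, a methoxy or an amine at this position would follow chloro or methyl stays open, as does whether chloro has the same effect on the core of compound 3. No available evidence bears on why chloro and methyl differ here.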